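Tolerated at the limit: from compound 3 to compound 4

The source may hold more compounds than are shown below. What is called first, only, known or untested is meant among the compounds shown, and "the series" means these compounds.

Values measured in a toxicity assay on HepG2 2.2.15 cells (Homo sapiens) for cytotoxicity, read by CellTiter-Glo (a higher number here means that more compound is tolerated, a lower number that less compound is tolerated), so far:
Compound 1 `O=C1CC(c2ncc(F)cn2)CN1c1cnn2c1CN(C(=O)Nc1cc(F)c(F)c(F)c1)C(C1CC1)C2` gives 115000 nM as an exact number
Compound 2 `O=C1CC(c2ncco2)CN1c1cnn2c1CN(C(=O)Nc1cc(F)c(F)c(F)c1)C(C1CC1)C2` gives > 200000 nM as a limit of the assay
Compound 3 `O=C1CC(c2ncccn2)CN1c1cnn2c1CN(C(=O)Nc1cc(F)c(F)c(F)c1)C(C1CC1)C2` gives > 200000 nM as a limit of the assay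

Compound 3 has only the limit > 200000 nM in this assay and no exact number. The data here rest largely on the limit of > 200000 nM in this assay, at which 2 of the 3 values shown sit, and not on exact readings.

Compound 4 `Cc1nc(C2CC(=O)N(c3cnn4c3CN(C(=O)Nc3cc(F)c(F)c(F)c3)C(C3CC3)C4)C2)no1` is still unmeasured. Its change from compound 3 5-methyl-1,2,4-oxadiazol-3-yl in place of pyrimidin-2-yl on a saturated ring carbon puts 5-methyl-1,2,4-oxadiazol-3-yl in place of pyrimidin-2-yl on a saturated ring carbon.

The closest measured swap in this place is a step that the two limits leave unreadable from compound 2 to compound 3 and it offers no size to carry over. Two other steps start from compound 1: the swap to 1,3-oxazol-2-yl gives an at least 1.7-fold higher number from compound 1 to compound 2 (0.24 log units; that floor lies within the scatter) and hydrogen in place of fluoro gives an at least 1.7-fold higher number from compound 1 to compound 3 (0.24 log units; that floor lies within the scatter) and neither floor lies beyond the scatter. Compound 2 also has only the limit > 200000 nM with a five-membered aromatic ring in this place.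

In this assay the expected step is a number no higher from compound 3 to compound 4 (the limit leaves the size open) and so nothing beyond the scatter in either direction. Compound 4 is estimated at 200000 nM with an expected range from 100000 nM to 400000 nM and the assay may well report only a limit.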

Compound 4, half-maximal cytotoxic concentration: > 200000 nM
Compound 4 gave a limit, no number; the forecaster's own chance of this, stated with the estimate: 65%; the middle value sits exactly at the limit.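

In this assay, a second five-membered aromatic ring, after the 1,3-oxazol-2-yl group of compound 2, is now shown on the saturated ring carbon, and compound 4, with 5-methyl-1,2,4-oxadiazol-3-yl, gives > 200000 nM, which is a limit of the assay. Within the data shown here, the one readable new step is an at least 1.7-fold higher number from compound 1 to compound 4 (0.24 log units; that floor lies within the scatter), so it does not set 5-methyl-1,2,4-oxadiazol-3-yl apart from 5-fluoropyrimidin-2-yl. The steps linking compound 4 with compound 2 and with compound 3 cannot be read, because they join limit to limit and no size can be taken from them: the limit of > 200000 nM in this assay, at which 3 of the 4 values shown sit.

As far as these compounds go, compound 1 alone has an exact number, so how much of compound 2, compound 3 or compound 4 cells would tolerate, and whether these three differ at all, stays open. Also open, from the compounds shown here alone, is whether an amine or a carboxylic acid on this saturated ring carbon would give an exact reading in this assay.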